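Sulfonamide Substituents on a Shared Core in Rat Trachea

A few compounds are considered here, and "the series" means these few. Any claim that something is new, unique, unknown or untested is made for them only; others in the source may bear on it.

Measured compounds: compound 1 `CC1(C)C=C(n2ccccc2=O)c2cc(S(=O)(=O)N=[N+]=[N-])ccc2O1`, 77.2%; compound 2 `CC1(C)C=C(n2ccccc2=O)c2cc(S(=O)(=O)NCCO)ccc2O1`, 87.9%; compound 3 `CC1(C)C=C(n2ccccc2=O)c2cc(S(=O)(=O)Nc3ccccc3)ccc2O1`, 7.85%; 88% (2 entries).

In a functional assay on the whole organism (trachea) with Rattus norvegicus as the target (on this read-out higher numbers stand for larger maximal responses and lower numbers for smaller maximal responses), compound 2 stands highest of the two single numbers, with compound 1 nearest and lower by a number 10.7 percentage points higher from compound 1 to compound 2 (beyond the scatter). Compound 4 `COc1ccc(NS(=O)(=O)c2ccc3c(c2)C(n2ccccc2=O)=CC(C)(C)O3)cc1` differs from compound 2 by 4-methoxyphenyl in place of 2-hydroxyethyl on a sulfonamide nitrogen. Among the compounds with values here, no measured step matches this change; the step from compound 1 to compound 2 concerns a different exchange, and the only guide to an aryl group on the sulfonamide nitrogen is the several entries of compound 3 in this assay, 7.85%; 88% (2 entries), whose entries disagree widely. The expected step of a number 17.9 percentage points lower from compound 2 to compound 4 (beyond the scatter) for compound 4 is therefore uncertain. Compound 4 is estimated at 70% in this assay, in a range from 10% to 95%.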

Compound 4, largest response reached (Emax), in percent of the reference or control that the assay uses: 84.2%
The estimate for compound 4 lay 14.2 percentage points below the measured number, within the range that was stated.
By their numbers in this assay, from the lowest: compounds 1, 4 and 2 (each within the scatter of the next, the first and the last beyond it).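

Swapping the small chain for an aryl group on this nitrogen changes the response little in this assay: 4-methoxyphenyl in place of 2-hydroxyethyl gives a number 3.7 percentage points lower from compound 2 to compound 4 (within the scatter). The exchange of azido for (4-methoxyphenyl)amino on the sulfonyl sulfur also stays small, with a number 7 percentage points higher from compound 1 to compound 4 (within the scatter). An aryl-bearing sulfonamide therefore now has a single clear number, which the low entry for compound 3 does not match: the several entries of compound 3 in this assay, 7.85%; 88% (2 entries)

Which entry for compound 3 holds remains open. So does whether an amine or a carboxylic acid on this nitrogen, or a longer chain, would keep the response.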